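Adding a methoxy group to compound 2 of the series

This account rests on a few compounds, and the source may have more. Where it says the series, first, only, none or still open, it means among the compounds named here.

In a functional assay on SK-MEL-5 cells (Homo sapiens) for cytotoxicity, read by sulforhodamine B assay, with a stated time of 48 h, tested at 100 uM (a higher number here means a weaker effect of the compound at the concentration tested, a lower number a stronger effect), compound 1 `COc1cc(-c2cc(/C=C/C(=O)c3ccc(N)cc3)[nH]n2)cc(OC)c1OC` gives -94% and compound 2 `COc1ccc(C(=O)/C=C/c2cc(-c3cc(OC)c(OC)c(OC)c3)n[nH]2)cc1OC` gives -92%; the step between them, a number 2 percentage points higher from compound 1 to compound 2 (within the scatter), lies within the scatter, so compound 2 stands alongside compound 1 on the two numbers shown. Compound 3 `COc1cc(C(=O)/C=C/c2cc(-c3cc(OC)c(OC)c(OC)c3)n[nH]2)cc(OC)c1OC` differs from compound 2 by methoxy in place of hydrogen on an aromatic carbon. Among the measured compounds shown here, no measured step bears directly on this change; the only step, a number 2 percentage points higher from compound 1 to compound 2 (within the scatter), concerns a different group and was itself within the scatter. The step of a number 2 percentage points higher from compound 2 to compound 3 (within the scatter) is therefore expected to stay within the scatter, with no direction claimed. Compound 3 is estimated at -90%, between -100% and -72%.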

Compound 3, a percentage reported as activity, at one concentration (the size of the read-out at that concentration, not a potency): -98%
Compound 3: middle estimate off by 8 percentage points, on the high side; measured number inside the range.
By their numbers in this assay, from the lowest: compounds 3, 1 and 2 (each within the scatter of the next).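

In this assay, methoxy in place of hydrogen on an aromatic carbon, ortho to a methoxy group, gives a number 6 percentage points lower from compound 2 to compound 3 (within the scatter). Among the compounds shown here, this is the first reading at this position, and the added methoxy does not separate compound 3 from compound 2 on this read-out. No measurement on hand bears on why the read-out behaves this way.

As far as these compounds go, whether an amine or a carboxylic acid on the same aromatic carbon would also leave the read-out within the scatter stays open. A single concentration also leaves open how these compounds would compare at any other concentration; the read-out speaks only of a stronger or weaker effect at the concentration tested.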